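From Compound 2 to Compound 3 on a Carbonyl Carbon

The compounds below may be only part of what the source reports. "The series", "measured", "known", "first", "only" and "open" are said of these compounds alone.

In a functional assay on Caco-2 cells (Homo sapiens), read by MTT assay, with a stated time of 48 h (on this read-out higher numbers stand for weaker inhibition and lower numbers for stronger inhibition), compound 1 `CCn1c(C(=O)NCCN)ccc1C(CC)(CC)c1ccc(OCC(O)C(C)(C)C)c(C)c1` gives 1000 nM while compound 2 `CCn1c(C(=O)N(C)CC(=O)O)ccc1C(CC)(CC)c1ccc(OCC(O)C(C)(C)C)c(C)c1` gives 31900 nM as the higher of the two numbers. Compound 3 `CCn1c(C(=O)OCc2ccc(F)cc2)ccc1C(CC)(CC)c1ccc(OCC(O)C(C)(C)C)c(C)c1` differs from compound 2 by (4-fluorobenzyl)oxy in place of (carboxymethyl)(methyl)amino on a carbonyl carbon with (4-fluorobenzyl)oxy in place of (carboxymethyl)(methyl)amino on a carbonyl carbon. Within the data shown here, the only measured change at this carbonyl carbon is a 32-fold higher number from compound 1 to compound 2 (1.50 log units; beyond the scatter) and it is large and beyond the scatter, so a change in this place can move the number far. Among the measured compounds shown here, no measured compound carries the entering group, so only part of that size is expected in the opposite direction. In this assay an estimated step of a 5.3-fold lower number from compound 2 to compound 3 (0.73 log units; beyond the scatter) is expected, with wide uncertainty. The estimate for compound 3 is 6000 nM with 1500 nM to 25000 nM as the expected range.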

Compound 3, half-maximal inhibitory concentration: > 50000 nM
Compound 3 gave a limit, no number (the forecaster's own chance of this, stated with the estimate: 12%); middle value at least 8.3-fold (0.92 log units) from the limit.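

In this assay compound 3 gives a limit and not a number: the limit of > 50000 nM in this assay, at which 1 of the 3 values shown sits. With (4-fluorobenzyl)oxy on the carbonyl carbon there is an at least 50-fold higher number from compound 1 to compound 3 (1.69 log units; beyond the scatter), so a second, quite different replacement of (2-aminoethyl)amino also moves the number far upward, and among the compounds shown only compound 1 stays well below the limit. Against compound 2 the reading is an at least 1.5-fold higher number from compound 2 to compound 3 (0.19 log units; that floor lies within the scatter), so this floor alone does not separate (4-fluorobenzyl)oxy from (carboxymethyl)(methyl)amino.

The compounds shown do not tell whether the amine in (2-aminoethyl)amino is what sets compound 1 apart, or whether the amide link at this carbonyl carbon also plays a part. A hydroxyl in place of that amine, or a longer chain ending in an amine, would bear on this question.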